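Para substituent swap on the benzoyl ring of compound 3

The source may hold more compounds than are shown below. What is called first, only, known or untested is meant among the compounds shown, and "the series" means these compounds.

The measured compounds:
compound 1 `CC(C)(C)N(NC(=O)c1ccccc1Cl)C(=O)c1ccccc1Cl` gives 331 nM in an assay on cells for agonist activity at ecdysone receptor (Bombyx mori), read by a luciferase reporter, with a stated time of 24 h; on this read-out higher numbers stand for an effect only at larger amounts of compound and lower numbers for an effect already at smaller amounts;
compound 2 `CC(C)(C)N(NC(=O)c1ccccc1Br)C(=O)c1ccccc1Cl` gives 316 nM;
compound 3 `CC(C)(C)N(NC(=O)c1ccc(F)cc1)C(=O)c1ccccc1Cl` gives 389 nM.

All three share one core and differ only in one benzoyl ring. Compound 3 stands apart from neither of the others: the step of a 1.2-fold higher number from compound 1 to compound 3 (0.07 log units; within the scatter) and the step of a 1.2-fold higher number from compound 2 to compound 3 (0.09 log units; within the scatter) are both within the scatter, and the step of a 1.0-fold lower number from compound 1 to compound 2 (0.02 log units; within the scatter) is as well. Three different aromatic halogen patterns thus give numbers that cannot be told apart.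

Compound 4 `CC(C)(C)N(NC(=O)c1ccc(C#N)cc1)C(=O)c1ccccc1Cl` is the next variation. The change from compound 3 is cyano in place of fluoro on an aromatic carbon. Within the data shown here, no measured step exchanges a halogen for a cyano group, so the closest guides are the ring-substituent swaps already seen, none of which moved the number beyond the scatter. The expectation is therefore a step of a 1.1-fold higher number from compound 3 to compound 4 (0.03 log units; within the scatter), with no direction beyond the scatter. Compound 4 is estimated at 420 nM, with a range from 150 nM to 1200 nM.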

Compound 4, half-maximal effective concentration: 603 nM
Compound 4: middle estimate off by 1.4-fold (0.16 log units), on the low side; low and high end bracket the measured number.
By their numbers in this assay, from the lowest: compounds 2, 1, 3 and 4 (each within the scatter of the next).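

Among these compounds, compound 4 is the first compound here to carry something other than a halogen on this ring: a cyano group, para to a large group, with two heavy atoms where fluoro has one, plus a hydrogen-bond acceptor that fluoro does not have. In this assay this exchange gives a 1.6-fold higher number from compound 3 to compound 4 (0.19 log units; within the scatter) and the wider comparisons give a 1.9-fold higher number from compound 2 to compound 4 (0.28 log units; within the scatter) and a 1.8-fold higher number from compound 1 to compound 4 (0.26 log units; within the scatter) so the change of group type still leaves all four compounds within the scatter of one another. No separate measurement bears on this result.

From the compounds shown here alone, only fluoro and cyano appear at this place, so it remains open whether an amine, a carboxylic acid or a longer alkyl chain would also leave the number within the scatter. The other aromatic ring is the same in all four compounds, so these data say nothing about changes there.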